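This account rests on a few compounds, and the source may have more. Where it says the series, first, only, none or still open, it means among the compounds named here.

In a functional assay on PC-3 cells (Homo sapiens) for inhibition, read by MTT assay, with a stated time of 48 h (a lower number here means a stronger inhibitor, a higher number a weaker inhibitor), three compounds sharing one core have been measured. Compound 1 `COc1ccc(-n2c(SCc3ccc(C)cc3)nnc2-c2cc(OC)c(OC)c(OC)c2)cc1` gives 56500 nM, compound 2 `COc1ccc(CSc2nnc(-c3cc(OC)c(OC)c(OC)c3)n2-c2ccc(OC)cc2)cc1` gives 40300 nM, and compound 3 `COc1ccc(-n2c(SCC(=O)C3CC3)nnc2-c2cc(OC)c(OC)c(OC)c2)cc1` gives 37200 nM, so compound 3 stands level with the other two within the scatter. Compound 4 `COc1ccc(-n2c(SCC(=O)Nc3ccc(Cl)cc3)nnc2-c2cc(OC)c(OC)c(OC)c2)cc1` carries (4-chlorophenyl)amino in place of cyclopropyl on a carbonyl carbon. The evidence is indirect. The a 1.5-fold lower number from compound 1 to compound 3 (0.18 log units; within the scatter) and a 1.1-fold lower number from compound 2 to compound 3 (0.03 log units; within the scatter) both exchange the group on a saturated chain carbon bound to a sulfur, and a 1.4-fold lower number from compound 1 to compound 2 (0.15 log units; within the scatter) swaps methyl for methoxy. All three stay within the scatter, and none tests this exchange. The expected step in this assay is a 1.2-fold lower number from compound 3 to compound 4 (0.09 log units; within the scatter), thus none beyond the scatter. For compound 4 the estimated value is 30000 nM, ranging from 9000 nM to 70000 nM.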

Compound 4, half-maximal inhibitory concentration: 6290 nM
Compound 4: middle estimate off by 4.8-fold (0.68 log units), on the high side, and the stated range ends above it.
By their numbers in this assay, from the lowest: compound 4; then compounds 3, 2 and 1 (each within the scatter of the next).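

In this assay, within the data shown here, the carbonyl carbon is the first place in this set where an exchange goes beyond the scatter, with a 5.9-fold lower number from compound 3 to compound 4 (0.77 log units; beyond the scatter). Among these compounds, the whole side chain on sulfur responds as well, with a 6.4-fold lower number from compound 2 to compound 4 (0.81 log units; beyond the scatter) and a 9.0-fold lower number from compound 1 to compound 4 (0.95 log units; beyond the scatter), whereas the exchanges among the earlier compounds all stayed within the scatter. Nothing given here explains this step.

The amide hydrogen and the 4-chlorophenyl ring enter together, and the compounds shown do not separate their contributions. On these data alone, how a methylamino group or an unsubstituted phenylamino group would read on the same carbonyl carbon remains open.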